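The compounds below may be only part of what the source reports. "The series", "measured", "known", "first", "only" and "open" are said of these compounds alone.

In a functional assay on SW-620 cells (Homo sapiens) for inhibition, read by MTT assay, with a stated time of 72 h (on this read-out lower numbers stand for stronger inhibition and higher numbers for weaker inhibition), compound 1 `COc1cc(NC(C)CCCNC(=O)Nc2cccc(Cl)c2)c2ncccc2c1` gives 26000 nM, compound 2 `COc1cc(NC(C)CCCNC(=O)NNC(=O)Nc2ccc(Cl)cc2)c2ncccc2c1` gives 48000 nM and compound 3 `COc1cc(NC(C)CCCNC(=O)Nc2cccc(O)c2)c2ncccc2c1` gives 27000 nM. Compound 3 is not separated from either of the other two: a 1.0-fold higher number from compound 1 to compound 3 (0.02 log units; within the scatter) and a 1.8-fold lower number from compound 2 to compound 3 (0.25 log units; within the scatter) both lie within the scatter, as does a 1.8-fold higher number from compound 1 to compound 2 (0.27 log units; within the scatter). Compound 4 `COc1cc(NC(C)CCCNC(=O)Nc2cccc(C(F)(F)F)c2)c2ncccc2c1` differs from compound 3 in one place, with trifluoromethyl in place of hydroxy on an aromatic carbon. The closest measured precedent is the exchange of chloro for hydroxy on an aromatic carbon, which links compound 1 and compound 3 and amounts to a 1.0-fold higher number from compound 1 to compound 3 (0.02 log units; within the scatter). No measured compound carries trifluoromethyl, so this single flat step is thin support, but it gives no reason to expect a change beyond the scatter in this assay. The estimated step is a 1.1-fold lower number from compound 3 to compound 4 (0.05 log units; within the scatter). Compound 4 is expected at about 24000 nM, with an estimated range from 11000 nM to 50000 nM.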

Compound 4, half-maximal inhibitory concentration: 22000 nM
For compound 4 the middle estimate is 1.1-fold (0.04 log units) above the measured one; the range from low to high includes it.
By their numbers in this assay, from the lowest: compounds 4, 1, 3 and 2 (each within the scatter of the next, the first and the last beyond it).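

In this assay, replacing hydroxy with trifluoromethyl, a group with no hydrogen-bond donor or acceptor, gives a 1.2-fold lower number from compound 3 to compound 4 (0.09 log units; within the scatter), and replacing chloro with it gives a 1.2-fold lower number from compound 1 to compound 4 (0.07 log units; within the scatter). Chloro, hydroxy and trifluoromethyl on this aromatic carbon are therefore not separated, so the flat result no longer rests on the chloro and hydroxy pair alone. Going by these compounds alone, the one step beyond the scatter is modest, a 2.2-fold lower number from compound 2 to compound 4 (0.34 log units; beyond the scatter), and it exchanges the whole ((4-chlorophenyl)carbamoyl)amino group rather than a substituent at this position, so it shows nothing about this carbon.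

Nothing measured here accounts for the lack of separation among these three groups. Going by these compounds, whether an amine, a carboxylic acid or a second aromatic ring on this carbon would move the number beyond the scatter remains open.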